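A few compounds are considered here, and "the series" means these few. Any claim that something is new, unique, unknown or untested is made for them only; others in the source may bear on it.

Of the compounds shown here, three that share one core have been tested in an assay on isolated protein for inhibition of NUAK family SNF1-like kinase 1 (Homo sapiens), read by ADP-Glo, with a stated time of 60 min, tested at 10 uM, in the presence of a further agent that is not named here; on this read-out lower numbers stand for less inhibition and higher numbers for more inhibition at the one concentration tested (going by the name of the read-out). Compound 1 `CCC(=O)Nc1cccc(Oc2nc(Nc3ccc(N4CCN(C)CC4)cc3)ncc2Cl)c1` gives 92.9%, the highest of the three numbers. Compound 3 `CCC(=O)Nc1cccc(Oc2ccnc(Nc3ccc(N4CCN(C)CC4)cc3)n2)c1`, which carries hydrogen in place of chloro on an aromatic carbon, gives 85.6%; the step of a number 7.3 percentage points lower from compound 1 to compound 3 (within the scatter) lies within the scatter, so the two stand together. Compound 2 `CCC(=O)Nc1cccc(Oc2nc(Nc3ccc(N4CCC(OC)CC4)cc3OC)ncc2Cl)c1` gives 5.08%, far below compound 1, but it differs from compound 1 in several places at once, so no single change can be read from that gap.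

Compound 4 `CCC(=O)Nc1cccc(Oc2nc(Nc3ccc(N4CCCCC4)cc3)ncc2Cl)c1` has not yet been measured. It differs from compound 1 in one place: piperidin-1-yl in place of 4-methylpiperazin-1-yl on an aromatic carbon. The exchange sits on an aromatic carbon of a six-membered aromatic ring of carbon only, para to a large group. Within the data shown here, none of the measured steps touches this place; the only single-change step, a number 7.3 percentage points lower from compound 1 to compound 3 (within the scatter), concerns a different position and stayed within the scatter. There is thus no direct guide, and the expectation rests on compound 1 giving 92.9%. Compound 4 is expected to give a number close to that of compound 1, with a step of a number 12.9 percentage points lower from compound 1 to compound 4 (beyond the scatter) that may fall within the scatter or slightly beyond it. The estimate for compound 4 is 80%, with a range from 50% to 95%.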

Compound 4, a percentage reported as inhibition, at one concentration (the size of the read-out at that concentration, not a potency): 86%
Beside the measured number, compound 4's estimate is 6 percentage points below it; the range from low to high includes it.
By their numbers in this assay, from the lowest: compound 2; then compounds 3, 4 and 1 (each within the scatter of the next).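

The exchange of 4-methylpiperazin-1-yl for piperidin-1-yl, on an aromatic carbon of a six-membered aromatic ring of carbon only, gives a number 6.9 percentage points lower from compound 1 to compound 4 (within the scatter) in this assay, and this is the first step shown at this place. For this one pair, the second ring nitrogen and the methyl group it carries can therefore be removed without moving the reading beyond the usual scatter, so the high number does not depend on them at the one concentration tested. No measurement of any property of these two groups is available to account for this result.

From the compounds shown here alone, both groups compared here are six-membered rings joined through a ring nitrogen, so it remains open whether morpholin-4-yl, an open-chain dimethylamino group or a carboxylic acid at this place would keep the number as high. A reading at a single concentration is also not a potency, and compounds 1 and 4 could still differ at lower concentrations, which a full dose-response measurement would be needed to show.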